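A few compounds are considered here, and "the series" means these few. Any claim that something is new, unique, unknown or untested is made for them only; others in the source may bear on it.

The measured compounds in a functional assay on PC-3 cells (Homo sapiens) for cytotoxicity, read by MTT assay, with a stated time of 72 h (a lower number here means a stronger inhibitor, a higher number a weaker inhibitor), are:

Compound 1, `CCC[C@H](Nc1cc(-c2ccc(NC(=O)NCC)c(OC)c2)ncn1)c1cccnc1`, with 100 nM
Compound 2, `CCC[C@H](Nc1ccnc(-c2ccc(NC(=O)NCC)c(OC)c2)n1)c1cccnc1`, with 150 nM
Compound 3, `CCC[C@H](Nc1cc(-c2ccc(NC(=O)NCC)c(OC)c2)nc(C)n1)c1cccnc1`, with 80 nM

All three share the same side chains and differ only in the core. Compound 3 is compound 1 with one change, (methyl in place of hydrogen on an aromatic carbon); the step it made in this assay was a 1.3-fold lower number from compound 1 to compound 3 (0.10 log units; within the scatter), so the two compounds sit together within the usual scatter. Compound 2 has the same atoms as compound 1 joined differently; the difference between the two cores is not broken down here. Its value in this assay lies within the scatter of both compound 1 and compound 3, so no order among the three can be read from these numbers.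

Compound 4, `CCC[C@H](Nc1cc(C)nc(-c2ccc(NC(=O)NCC)c(OC)c2)n1)c1cccnc1`, has not yet been measured. It stands to compound 2 as compound 3 stands to compound 1: methyl in place of hydrogen on an aromatic carbon. It is the same kind of change, not the same one, since in compound 3 the methyl sits between two ring nitrogen atoms, whereas in compound 4 it sits next to the ring nitrogen and opposite the ring nitrogen. Resting on the measured pair, where the step was a 1.3-fold lower number from compound 1 to compound 3 (0.10 log units; within the scatter), the expected step from compound 2 to compound 4 is a 1.3-fold lower number from compound 2 to compound 4 (0.10 log units; within the scatter). On that basis compound 4 is estimated to give 120 nM in this assay, expected to fall between 60 nM and 250 nM.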

Compound 4, half-maximal inhibitory concentration: 200 nM
Estimate against measurement, compound 4: 1.7-fold (0.22 log units) below; the measured number falls inside the stated range.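

In this assay, methyl in place of hydrogen on an aromatic carbon of the core of compound 2 gives a 1.3-fold higher number from compound 2 to compound 4 (0.12 log units; within the scatter), so this pair, like the pair on the core of compound 1, sits together within the usual scatter. Set side by side, the two steps cannot be told apart: the same change on two cores in this assay, a 1.3-fold lower number (0.10 log units; within the scatter) from compound 1 to compound 3 and a 1.3-fold higher number (0.12 log units; within the scatter) from compound 2 to compound 4, 1.7-fold (0.22 log units) apart, within the scatter of two such steps

This shows that on both cores the methyl leaves the number within the scatter, so a step too small to read has carried over from one core to the other; it does not show that the change acts alike on the two cores, for steps this small can give neither a shared direction nor a shared size, and the methyl does not stand in the same place relative to the ring nitrogen atoms in compound 3 and compound 4.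

At this carbon the compounds shown carry only hydrogen or methyl, which leaves open whether a chlorine, a trifluoromethyl or a cyclopropyl there would give a step beyond the scatter, and whether such a step would then carry from one core to the other. As far as these compounds go, the side chains are the same in all four compounds, so what a longer chain in place of the propyl would do on either core also stays open.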